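Permeability of an oxazole piperidine amide series

The source may hold more compounds than are shown below. What is called first, only, known or untested is meant among the compounds shown, and "the series" means these compounds.

Measured compounds:
compound 1, `Cc1oc(-c2ccccc2Cl)nc1CN1CCC(C(=O)NCCCN2C[C@H](C)C[C@H](C)C2)CC1`: 352 10^-6 cm/s
compound 2, `Cc1ccccc1-c1nc(CN2CCC(C(=O)N3CCN(CCN(C)C)CC3)CC2)c(C)o1`: 14 10^-6 cm/s

In a physicochemical assay for permeability, using PAMPA (on this read-out higher numbers stand for higher permeability and lower numbers for lower permeability), compound 1 gives 352 10^-6 cm/s, the higher of the two numbers; compound 2 gives 14 10^-6 cm/s, a gap that lies beyond the scatter. Compound 3, `COc1cccc(C)c1-c1nc(CN2CCC(C(=O)NCCCN3C[C@H](C)C[C@H](C)C3)CC2)c(C)o1`, has not yet been measured. It differs from compound 1 in one place: 2-methoxy-6-methylphenyl in place of 2-chlorophenyl on an aromatic carbon. For the measured compounds named here, no measured pair shows the effect of such a change, so the step is expected to be small, a slight lowering at most, a 1.4-fold lower number from compound 1 to compound 3 (0.15 log units; within the scatter), and likely within the scatter. For compound 3 an estimate of 250 10^-6 cm/s is made, with a range from 100 10^-6 cm/s to 500 10^-6 cm/s.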

Compound 3, apparent permeability: 198 10^-6 cm/s
Estimate against measurement, compound 3: 1.3-fold (0.10 log units) above; measured number inside the range.
By their numbers in this assay, from the lowest: compound 2; then compounds 3 and 1 (each within the scatter of the next).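

In this assay, for the compounds shown here, 2-methoxy-6-methylphenyl in place of 2-chlorophenyl gives a 1.8-fold lower number from compound 1 to compound 3 (0.25 log units; within the scatter), the first reading of any change at this aromatic carbon. Compound 1 and compound 3 therefore cannot be told apart here, although the entering group holds one hydrogen-bond acceptor and the leaving group none. No measurement shown offers a reason for this result.

From the compounds shown here alone, it remains open whether an amine or a carboxylic acid on this phenyl ring would move the number beyond the scatter. Also open, going by these compounds, is what the methoxy and methyl groups each do alone.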